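Swapping methyl for acetoxy on the saturated chain

This account rests on a few compounds, and the source may have more. Where it says the series, first, only, none or still open, it means among the compounds named here.

In a functional assay on OCI-My4 cells (Homo sapiens) for antiproliferative activity, read by MTT assay, with a stated time of 72 h (a higher number here means a weaker inhibitor, a lower number a stronger inhibitor), compound 1 (`CC[C@H](NC(=O)/C(C#N)=C/c1cccc(Br)n1)c1ccccc1`) gives 1700 nM and compound 2 (`N#C/C(=C\c1cccc(Br)n1)C(=O)NC(c1ccccc1)C1CC1`) gives 1600 nM (a pair within the usual scatter of each other). Compound 3 (`CC(=O)OC[C@H](NC(=O)/C(C#N)=C/c1cccc(Br)n1)c1ccccc1`) has acetoxy in place of methyl on a saturated chain carbon, two bonds along the chain from an amide-type nitrogen and an aromatic carbon. Going by the values given here, no measured pair shows this change, so the expectation starts from compound 1 at 1700 nM and stays cautious. In this assay the expected move is small, towards a weaker number and probably within the scatter (a 1.3-fold higher number from compound 1 to compound 3 (0.11 log units; within the scatter)). For compound 3 the estimated value is 2200 nM (expected range 800 nM to 6000 nM).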

Compound 3, half-maximal inhibitory concentration: 2900 nM
Beside the measured number, compound 3's estimate is 1.3-fold (0.12 log units) below it; the range from low to high includes it.
By their numbers in this assay, from the lowest: compounds 2, 1 and 3 (each within the scatter of the next).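

In this assay, acetoxy in place of methyl on this saturated chain carbon gives a 1.7-fold higher number from compound 1 to compound 3 (0.23 log units; within the scatter). So this carbon carries a group of four heavy atoms, with two hydrogen-bond acceptors, where methyl had one heavy atom, without a change that can be told from the scatter. No measurement here offers an explanation for this result. Still open, on these data alone, is how an amine, a carboxylic acid or a longer chain on the same carbon would read in this assay.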